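Cyclohexyl to benzyl swap on the imidazole nitrogen

This account rests on a few compounds, and the source may have more. Where it says the series, first, only, none or still open, it means among the compounds named here.

In a functional assay on NCI/ADR-RES cells (Homo sapiens) for inhibition, read by sulforhodamine B assay, with a stated time of 48 h, tested at 10 uM (on this read-out lower numbers stand for less inhibition and higher numbers for more inhibition at the one concentration tested (going by the name of the read-out)), compound 1 `c1ccc2c(-c3cn4ccnc4c(-c4ccc5ncn(C6CCCCC6)c5c4)n3)cccc2c1` gives 4.43% and compound 2 `c1ccc(Cn2cnc3ccc(-c4nc(-c5cccc6ccccc56)cn5ccnc45)cc32)cc1` gives 5.83%. The two differ by benzyl in place of cyclohexyl on an aromatic nitrogen, a change that moves a number 1.4 percentage points higher from compound 1 to compound 2 (within the scatter); the two numbers sit within the scatter of each other, so no direction is read into them. Compound 3 `c1cn2cc(-c3ccc4c(c3)ncn4C3CCCCC3)nc(-c3ccc4ncn(C5CCCCC5)c4c3)c2n1` stands apart: in this assay compound 3 gives 27%, beyond the scatter relative to both compound 1 and compound 2. How the core of compound 3 differs from the core of compound 1 is not broken down here. Compound 4 `c1ccc(Cn2cnc3ccc(-c4nc(-c5ccc6c(c5)ncn6C5CCCCC5)cn5ccnc45)cc32)cc1` has not yet been measured in this assay. It differs from compound 3 by benzyl in place of cyclohexyl on an aromatic nitrogen, the same change as that from compound 1 to compound 2, at a place described in identical words. Because the earlier step was a number 1.4 percentage points higher from compound 1 to compound 2 (within the scatter) and lay within the scatter, compound 4 is expected to remain close to compound 3, with an estimated step of a number 1 percentage points higher from compound 3 to compound 4 (within the scatter). Among the measured compounds shown here, for compound 4 the expected reading is 28%, with a range from 14% to 42%; only one earlier instance of the change is known, so the range is kept wide.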

Compound 4, a percentage reported as inhibition, at one concentration (the size of the read-out at that concentration, not a potency): 99.5%
Compound 4: the middle estimate sits 71.5 percentage points below what was measured, outside the stated range (above it).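

In this assay, benzyl in place of cyclohexyl on an aromatic nitrogen gives a number 72.5 percentage points higher from compound 3 to compound 4 (beyond the scatter). The step therefore does not carry over at a fixed size between the two cores, and its size depends on the core carrying the change, at least for these two pairs: the same change on two cores in this assay, a number 1.4 percentage points higher (within the scatter) from compound 1 to compound 2 and a number 72.5 percentage points higher (beyond the scatter) from compound 3 to compound 4, 71.1 percentage points apart, beyond the scatter of two such steps. This does not show which feature of the core accounts for the gap, and two pairs give no rule for any further core in the series.

Open, as far as these compounds go, is how other groups on that aromatic nitrogen would read on the core of compound 3, such as a longer chain like phenethyl, or a benzyl carrying an amine or a carboxylic acid. Also open, from the compounds shown here alone, is whether the reading of compound 4 reflects potency, since a result at one concentration gives the size of the read-out there and not a concentration-response relationship.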